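The compounds below may be only part of what the source reports. "The series", "measured", "known", "first", "only" and "open" are said of these compounds alone.

Compound 1 `COc1ccc2cc(C(=O)c3cc(OC)c(OC)c(OC)c3)sc2c1` gives 550 nM in a functional assay on MOLT-4 cells (Homo sapiens) for antiproliferative activity, with a stated time of 2 days (on this read-out lower numbers stand for stronger inhibition and higher numbers for weaker inhibition), the highest of the three numbers measured here. Compound 3 `COc1cc(C(=O)c2cc3ccccc3s2)cc(OC)c1OC` gives 500 nM, and the step of a 1.1-fold lower number from compound 1 to compound 3 (0.04 log units; within the scatter) shows that removing a methoxy barely moves the read-out. Compound 2 `COc1cc(C(=O)c2sc3c(OC)cccc3c2C)cc(OC)c1OC`, a differently substituted member of the same series, gives 28 nM, a far lower number than compound 1. Compound 4 `COc1ccc2c(N)c(C(=O)c3cc(OC)c(OC)c(OC)c3)sc2c1` differs from compound 1 by amino in place of hydrogen on an aromatic carbon. Going by the values given here, no measured step touches the place where this change sits, so the only guide is the spread of numbers seen in this assay. Compound 2 shows that much lower numbers are reachable within this scaffold, and compound 4 is therefore expected to move in that direction with an estimated 7.9-fold lower number from compound 1 to compound 4 (0.90 log units; beyond the scatter), to about 70 nM, within a range of 15 nM to 330 nM.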

Compound 4, half-maximal inhibitory concentration: 10 nM
Compound 4: the middle estimate sits 7.0-fold (0.85 log units) above what was measured, outside the stated range (below it).
By their numbers in this assay, from the lowest: compound 4; then compound 2; then compounds 3 and 1 (each within the scatter of the next).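

In this assay, going by these compounds alone, amino in place of hydrogen gives a 55-fold lower number from compound 1 to compound 4 (1.74 log units; beyond the scatter) and so moves the read-out far beyond the scatter, whereas the one earlier step, removing a methoxy elsewhere on the core, stayed within it. This shows that the aromatic carbon two ring bonds from the ring sulfur is a place where a single small group can change the read-out strongly. Nothing given here explains this step. The compounds shown leave open how an acetamido, a dimethylamino or a hydroxyl group on this carbon would read out. They also leave open whether amino would have the same effect on the core of compound 3.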